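Solubility after swapping the saturated ring for an aryl group

A few compounds are considered here, and "the series" means these few. Any claim that something is new, unique, unknown or untested is made for them only; others in the source may bear on it.

Compound 1 `COCC1CCN(c2nccnc2OC2CN(c3ccc4ccccc4n3)C2)CC1` is a member of the series with its six-membered non-aromatic ring bearing a methoxymethyl group. In a physicochemical assay for solubility, in phosphate buffer, at pH 7.4 (on this read-out lower numbers stand for lower solubility and higher numbers for higher solubility), compound 1 gives 53000 nM, the lower of the two numbers recorded in this series. Its nearest neighbour is compound 2 `N#CC1CCN(c2nccnc2OC2CN(c3ccc4ccccc4n3)C2)CC1`, which in this assay gives 66000 nM; the change a 1.2-fold higher number from compound 1 to compound 2 (0.10 log units; within the scatter) lies within the scatter. Compound 3 `Cc1ccc(-c2nccnc2OC2CN(c3ccc4ccccc4n3)C2)cc1` in this assay gives < 1000 nM, which is a limit of the assay and not a number (the limit of < 1000 nM in this assay, at which 1 of the 3 values shown sits). The step of an at least 53-fold lower number from compound 1 to compound 3 (1.72 log units; beyond the scatter) and the step of an at least 66-fold lower number from compound 2 to compound 3 (1.81 log units; beyond the scatter) both carry a 4-methylphenyl onto the same aromatic carbon in place of a saturated ring.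

Compound 4 `Cc1ncccc1-c1nccnc1OC1CN(c2ccc3ccccc3n2)C1` is not yet measured. It differs from compound 1 by 2-methylpyridin-3-yl in place of 4-(methoxymethyl)piperidin-1-yl on an aromatic carbon. Both measured aryl-for-saturated-ring steps were large and downward, so a large drop in this assay is expected here too, though possibly not to the limit. For compound 4 the estimate is 3000 nM, with a range of 700 nM to 15000 nM. The expected step is therefore an 18-fold lower number from compound 1 to compound 4 (1.25 log units; beyond the scatter).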

Compound 4, solubility: 253000 nM
Estimate against measurement, compound 4: 84-fold (1.93 log units) below, and the stated range ends below it.
By their numbers in this assay, from the lowest: compounds 1 and 2 (each within the scatter of the next); then compound 4. At a limit, below all of these: compound 3.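

At this aromatic carbon, an aryl group does not by itself give a low number in this assay, as 2-methylpyridin-3-yl in place of 4-methylphenyl shows (an at least 250-fold higher number from compound 3 to compound 4 (2.40 log units; beyond the scatter)). Compound 4 also sits beyond the scatter of both saturated-ring compounds (a 4.8-fold higher number from compound 1 to compound 4 (0.68 log units; beyond the scatter); a 3.8-fold higher number from compound 2 to compound 4 (0.58 log units; beyond the scatter)), so the drop seen with compound 3 is no general result of replacing the saturated ring with an aryl group, and compound 4 goes against that reading. The value of compound 3 is a limit of the assay and not a number: the limit of < 1000 nM in this assay, at which 1 of the 4 values shown sits.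

The compounds shown do not separate the ring nitrogen of 2-methylpyridin-3-yl from its methyl group, as a plain pyridin-3-yl or 2-methylphenyl would. On these data alone, how an aryl group carrying an amine or a carboxylic acid would read in this assay also stays open.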